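Working notes: from compound 3 to compound 4

A few compounds are considered here, and "the series" means these few. Any claim that something is new, unique, unknown or untested is made for them only; others in the source may bear on it.

The series shares one core carrying an amino group and a branched diol side arm. Within the data shown here, compound 1 `CNc1nc(N)nc2c1ncn2/C=C1/CC1(CO)CO` is the only member with a number in an ADME assay on HFF cells (Homo sapiens) for cytotoxicity, with a stated time of 8 days; on this read-out higher numbers stand for lower toxicity in this test and lower numbers for higher toxicity in this test; compound 1 gives 265000 nM. Compound 2 `CCOc1nc(N)nc2c1ncn2/C=C1/CC1(CO)CO` reaches only a limit of the test, > 300000 nM. Compound 3 `CCCCCCCCOc1nc(N)nc2c1ncn2/C=C1/CC1(CO)CO` likewise stops at a limit, > 300000 nM. Both limit values sit at the limit of > 300000 nM in this assay, at which 2 of the 3 values shown sit. The steps joining these read an at least 1.1-fold higher number from compound 1 to compound 2 (0.05 log units; that floor lies within the scatter) and an at least 1.1-fold higher number from compound 1 to compound 3 (0.05 log units; that floor lies within the scatter), while a step that the two limits leave unreadable from compound 2 to compound 3.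

Compound 4 `Nc1nc(SC2CCCC2)c2ncn(/C=C3/CC3(CO)CO)c2n1` differs from compound 3 in cyclopentylsulfanyl in place of octyloxy on an aromatic carbon. Among the measured compounds shown here, no measured step exchanges an oxygen-linked group for a sulfur-linked one; the nearest are the swaps of methylamino into ethoxy and into octyloxy, each only a floor within the scatter, and hexyl in place of hydrogen, which cannot be read at all. Nothing here foretells a shift beyond the scatter in this assay in either direction. Compound 4 is expected to give 300000 nM, between 100000 nM and 600000 nM, most probably reported again as a limit. The step expected is a number no higher from compound 3 to compound 4 (the limit leaves the size open).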

Compound 4, half-maximal cytotoxic concentration: > 300000 nM
Compound 4: a limit, no number; the forecaster's own chance of this, stated with the estimate: 60%; the middle value lies on the limit itself.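

In this assay the aromatic carbon now carries a sulfur-linked group with a five-membered ring of carbon only, and compound 4 still gives a limit rather than a number, as the oxygen-linked ethoxy of compound 2 and octyloxy of compound 3 did. Among these compounds, the only readable step is an at least 1.1-fold higher number from compound 1 to compound 4 (0.05 log units; that floor lies within the scatter). The steps to compound 4 from compound 2 and from compound 3 cannot be read, and the series gathers at a single point: the limit of > 300000 nM in this assay, at which 3 of the 4 values shown sit.

Among the compounds shown here, whether any group at this aromatic carbon gives a clear drop in the number stays open, since compound 1, with methylamino, is the only member with a number, 265000 nM. On these data alone, how a cyclic amine such as piperidine or a carboxylic acid at this carbon would read in this assay also stays open.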